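Morpholine in place of pyrrolidine on a thiosemicarbazone

The compounds below may be only part of what the source reports. "The series", "measured", "known", "first", "only" and "open" are said of these compounds alone.

Three compounds sharing an amidrazone-thiocarbonyl core were tested in a functional assay on A-375 cells (Homo sapiens) for cytotoxicity, read by MTT assay, with a stated time of 72 h, tested at 100 uM; a higher number here means more inhibition of growth at the concentration tested, a lower number less inhibition of growth. Compound 1, `Cc1ccnc(/C(N)=N/NC(=S)N2CCCC2)c1`, gives 88.8% in this assay. Compound 2, `N/C(=N\NC(=S)N1CCSCC1)c1ccccn1`, gives 87.8% in this assay, and compound 3, `Cc1ccnc(/C(N)=N/NC(=S)N2CCCCCC2)c1`, gives 77% in this assay. Compound 1 carries the highest of the three numbers, though the number for compound 2 lies within the usual scatter of it, so nothing can be said about any order between these two; the number for compound 3 lies beyond the scatter and is lower than that of compound 1.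

Compound 4, `Cc1ccnc(/C(N)=N/NC(=S)N2CCOCC2)c1`, has not yet been measured. It differs from compound 1 in one place: morpholin-4-yl in place of pyrrolidin-1-yl on a thiocarbonyl carbon. For the measured compounds named here, no pair of measured compounds differs in exactly this way, so the size of the step cannot be read from the data.

Compound 4 is expected to give about 85% in this assay, with a range from 70% to 93%. This estimate rests on the near-equal numbers for compound 1 at 88.8% and compound 2 at 87.8%, and it means an expected step of a number 3.8 percentage points lower from compound 1 to compound 4 (within the scatter), which would lie within the scatter.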

Compound 4, percent growth inhibition at one concentration: 90.6%
Estimate against measurement, compound 4: 5.6 percentage points below; the range from low to high includes it.
By their numbers in this assay, from the lowest: compound 3; then compounds 2, 1 and 4 (each within the scatter of the next).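

Placing morpholin-4-yl in place of pyrrolidin-1-yl on a thiocarbonyl carbon gives, in this assay, a number 1.8 percentage points higher from compound 1 to compound 4 (within the scatter), so the two compounds cannot be told apart in this read-out. For the compounds shown here, this is the first step read at this place, and it shows that a six-membered non-aromatic ring with 2 hetero atoms, one of them a hydrogen-bond acceptor, can stand there while the number stays within the scatter of that for the five-membered ring. The data hold nothing that would explain this result or tie it to any property of either group.

Since these numbers all come from growth inhibition at a single concentration, they leave open whether compound 1 and compound 4 would also stay within the scatter of each other at lower concentrations. On these data alone, it also remains open how the number would respond at this place to a piperazin-1-yl ring, with a second ring nitrogen in place of the morpholine oxygen, or to an open-chain dimethylamino group.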